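Swapping a hydroxycyclohexyl ether for a hydroxybenzyl ether

The source may report more compounds than this note shows. Statements on the series, on what has been measured and on what is new or still open speak of the compounds shown alone.

Measured compounds:
compound 1, `O=C(NCCNS(=O)(=O)c1ccc(-c2ccccc2O[C@H]2CC[C@H](O)CC2)s1)Nc1cc(C(F)(F)F)cc(C(F)(F)F)c1`, 7100 nM
compound 2, `O=C(Nc1cccc([N+](=O)[O-])c1)N1CCN(S(=O)(=O)c2sccc2-c2ccccc2Oc2ccc(O)c(O)c2)CC1`, 4500 nM

The two measured compounds were tested in a functional assay on HL-60 cells (Homo sapiens) for inhibition, read by CCK-8 assay, with a stated time of 48 h; on this read-out lower numbers stand for stronger inhibition and higher numbers for weaker inhibition. Compound 1 gives 7100 nM, the higher of the two numbers. Compound 2 gives 4500 nM, and the gap between the two lies within the usual scatter, so the two compounds cannot be ordered on this read-out. The unmeasured compound 3, `O=C(NCCNS(=O)(=O)c1ccc(-c2ccccc2OCc2cccc(O)c2)s1)Nc1cc(C(F)(F)F)cc(C(F)(F)F)c1`, is built from compound 1 by one change: 3-hydroxybenzyl in place of 4-hydroxycyclohexyl on an oxygen on an aromatic ring. Among the compounds with values here, no pair of measured compounds that differ in one place is available, so the effect of this change is unknown and rests on the number for compound 1 alone. The step expected in this assay is none beyond the scatter, written as a 1.2-fold lower number from compound 1 to compound 3 (0.07 log units; within the scatter). Compound 3 is therefore estimated at 6000 nM, with a range from 2000 nM to 18000 nM.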

Compound 3, half-maximal inhibitory concentration: 4000 nM
Compound 3: middle estimate off by 1.5-fold (0.18 log units), on the high side; low and high end bracket the measured number.
By their numbers in this assay, from the lowest: compounds 3, 2 and 1 (each within the scatter of the next).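

In this assay, within the data shown here, the first readable step at this position is a 1.8-fold lower number from compound 1 to compound 3 (0.25 log units; within the scatter) and so, on an oxygen on an aromatic ring, 3-hydroxybenzyl and 4-hydroxycyclohexyl cannot be told apart. The position therefore takes a six-membered aromatic ring of carbon in place of a non-aromatic one, with both defined stereocentres gone, and the number does not move beyond the scatter. Nothing measured here accounts for this outcome.

The compounds shown leave open whether the hydroxyl itself counts for anything on this oxygen, and whether a carboxylic acid, an amine or a longer chain in its place would move the number beyond the scatter. From the compounds shown here alone, all of this rests on a single pair, so it also remains unknown whether the same change would read alike on the core of compound 2.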